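Methoxy to hydroxy in the compound 1 series

The source may report more compounds than this note shows. Statements on the series, on what has been measured and on what is new or still open speak of the compounds shown alone.

compound 1 `COc1nc2c(cc1Cc1cccc(Cl)c1F)c(=O)c(C(=O)O)cn2[C@H](CO)C(C)(C)C` gives 82%
compound 2 `COc1nc2c(cc1Cc1cccc(Cl)c1F)c(=O)c(C(=O)O)cn2[C@H](CO)CC(C)C` gives 92%

In an ADME assay on microsomes from liver (Homo sapiens) for metabolic stability, with a stated time of 30 min (on this read-out higher numbers stand for a more stable compound and lower numbers for a less stable compound), compound 1 stands at 82% and is level with compound 2 within the scatter. Compound 3 `CC(C)(C)[C@@H](CO)n1cc(C(=O)O)c(=O)c2cc(Cc3cccc(Cl)c3F)c(O)nc21` differs from compound 1 by hydrogen in place of methyl on an oxygen on an aromatic ring which is methoxy to hydroxy. Among the measured compounds shown here, the only measured step is a number 10 percentage points higher from compound 1 to compound 2 (within the scatter) with isobutyl in place of tert-butyl on a saturated chain carbon. It lies elsewhere and gives only weak guidance, so no shift beyond the scatter is expected in this assay and the range is kept wide. The expected step is a number 3 percentage points higher from compound 1 to compound 3 (within the scatter) as estimated here. For compound 3 the estimate is 85% with an expected range from 65% to 97% on this read-out.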

Compound 3, percent of the compound remaining: 87%
The estimate for compound 3 lay 2 percentage points below the measured number; the measured number falls inside the stated range.
By their numbers in this assay, from the lowest: compounds 1, 3 and 2 (each within the scatter of the next).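

In this assay hydrogen in place of methyl on an oxygen on an aromatic ring comes with a number 5 percentage points higher from compound 1 to compound 3 (within the scatter) and so methoxy and hydroxy stand level at this place, with tert-butyl kept on the chain. Among the compounds shown here, the earlier step spoke only of the saturated chain carbon; this is the first reading at the oxygen. Nothing available gives a reason for this result.

Still open, as far as these compounds go, is how an ethoxy group or an amine would read at this place. Also open, from the compounds shown here alone, is whether hydroxy reads the same alongside the isobutyl of compound 2.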